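From fluoro to ethyl on the outer phenoxy ring

This account rests on a few compounds, and the source may have more. Where it says the series, first, only, none or still open, it means among the compounds named here.

Compound 1, `N[C@@H](COP(=O)(O)OCCCOC(=O)CCc1ccccc1OCc1cccc(Oc2ccccc2)c1)C(=O)O`: 19.4%
Compound 2, `N[C@@H](COP(=O)(O)OCCCOC(=O)CCc1ccccc1OCc1cccc(Oc2cccc(Cl)c2)c1)C(=O)O`: 17.1%
Compound 3, `N[C@@H](COP(=O)(O)OCCCOC(=O)CCc1ccccc1OCc1cccc(Oc2ccc(F)cc2)c1)C(=O)O`: 18.7%

Three compounds share one core and differ only at the outer phenoxy ring. In an assay on cells for agonist activity at probable G-protein coupled receptor 34 (Mus musculus), with a stated time of 1 h (a higher number here means a larger maximal response, a lower number a smaller maximal response), compound 1 gives 19.4%, compound 2 gives 17.1% and compound 3 gives 18.7%. Compound 3 stands second highest of the three numbers, but the step of a number 0.7 percentage points lower from compound 1 to compound 3 (within the scatter) and the step of a number 1.6 percentage points higher from compound 2 to compound 3 (within the scatter) both lie within the scatter, so the three values cannot be told apart.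

Compound 4, `CCc1ccc(Oc2cccc(COc3ccccc3CCC(=O)OCCCOP(=O)(O)OC[C@H](N)C(=O)O)c2)cc1`, is not yet measured. It differs from compound 3 in one place: ethyl in place of fluoro on an aromatic carbon. The measured steps that bear on this change are a number 0.7 percentage points lower from compound 1 to compound 3 (within the scatter), where fluoro entered in place of hydrogen, and a number 2.3 percentage points lower from compound 1 to compound 2 (within the scatter), where chloro entered; both stayed within the scatter. Among the compounds with values here, no measured compound carries an ethyl group, so that group itself is untested here. Since the steps of a number 2.3 percentage points lower from compound 1 to compound 2 (within the scatter) and a number 0.7 percentage points lower from compound 1 to compound 3 (within the scatter) stayed within the scatter, the step of a number 0.3 percentage points higher from compound 3 to compound 4 (within the scatter) is expected to stay within the scatter as well. Compound 4 is therefore estimated at 19%, with a range from 10% to 28%.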

Compound 4, largest response reached (Emax), in percent of the reference or control that the assay uses: 19.3%
Compound 4: the middle estimate sits 0.3 percentage points below what was measured, and the stated range covers the measured number.
By their numbers in this assay, from the lowest: compounds 2, 3, 4 and 1 (each within the scatter of the next).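

Within the data shown here, compound 4 brings a carbon group, ethyl, to the outer phenoxy ring, where the earlier compounds carried only hydrogen, fluoro or chloro. The steps are a number 0.6 percentage points higher from compound 3 to compound 4 (within the scatter), a number 0.1 percentage points lower from compound 1 to compound 4 (within the scatter) and a number 2.2 percentage points higher from compound 2 to compound 4 (within the scatter), so in this assay all four compounds remain indistinguishable, and swapping fluoro for ethyl at this place, para to a large group, gives no readable difference in maximal response. Nothing available explains why these values stay so close.

Still open, going by these compounds, is whether a longer chain such as hexyl, an amine or a carboxylic acid at the same place would give a step beyond the scatter. On these data alone, it is also open whether ethyl placed elsewhere on the outer phenoxy ring would give the same picture.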